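This account rests on a few compounds, and the source may have more. Where it says the series, first, only, none or still open, it means among the compounds named here.

Three compounds have been measured in a functional assay on SK-MEL-2 cells (Homo sapiens) for inhibition, read by sulforhodamine B assay, with a stated time of 48 h; on this read-out lower numbers stand for stronger inhibition of growth and higher numbers for weaker inhibition of growth:

- compound 1 `Nc1cc(N)c2nc(-c3ccccc3)c(Oc3ccc(Cl)c(Cl)c3)nc2c1` gives 5620 nM
- compound 2 `Nc1cc(N)c2nc(-c3ccccc3)c(NCc3ccc(Cl)c(Cl)c3)nc2c1` gives 1910 nM
- compound 3 `CCOC(=O)[C@H](CCC(=O)O)NC(=O)c1ccc(Sc2nc3cc(N)cc(N)c3nc2-c2ccccc2)cc1` gives 19100 nM

Among these three numbers compound 1 stands second highest. Its nearest neighbour is compound 2, whose number is lower by a margin beyond the usual scatter, and its furthest is compound 3, whose number is higher by a margin also beyond the scatter.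

Compound 4 `Nc1cc(N)c2nc(-c3ccccc3)c(Sc3ccc(F)cc3)nc2c1` is not yet measured. It differs from compound 1 in one place: (4-fluorophenyl)sulfanyl in place of 3,4-dichlorophenoxy on an aromatic carbon. For the measured compounds named here, no pair of measured compounds differing in a single place is available to guide this change, so the step from compound 1 to compound 4 is expected to be small, a 1.1-fold lower number from compound 1 to compound 4 (0.05 log units; within the scatter), with no clear direction beyond the scatter. Compound 4 is therefore estimated at 5000 nM, within a range of 1500 nM to 16000 nM.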

Compound 4, concentration for 50% growth inhibition: 38000 nM
Estimate against measurement, compound 4: 7.6-fold (0.88 log units) below; the measured number lies above the stated range.
By their numbers in this assay, from the lowest: compound 2; then compound 1; then compounds 3 and 4 (each within the scatter of the next).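

In this assay, for the compounds shown here, this position on the shared core proves sensitive to its group: with (4-fluorophenyl)sulfanyl in place of 3,4-dichlorophenoxy there is a 6.8-fold higher number from compound 1 to compound 4 (0.83 log units; beyond the scatter) as the first single-place step here. The two groups are close in heavy-atom count and each holds one carbon-only aromatic ring, yet the step lies beyond the scatter. No measurement at hand explains it.

Sulfur replaces oxygen and fluorine replaces both chlorines in the same step, so the contribution of each remains open. A (3,4-dichlorophenyl)sulfanyl group would separate these two changes.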